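The source may hold more compounds than are shown below. What is called first, only, known or untested is meant among the compounds shown, and "the series" means these compounds.

Compounds measured in a functional assay on CHO cells for positive allosteric modulation of metabotropic glutamate receptor 2 (Homo sapiens), read by scintillation counting and GTPgammaS binding, with a stated time of 30 min; a lower number here means that less compound is needed, a higher number that more compound is needed for the effect:
compound 1 `CCCn1ccc2c(OCCc3ccc(OC)cc3)cccc2c1=O`, 251 nM
compound 2 `CCCn1ccc2c(NCc3ccccc3)cccc2c1=O`, 2000 nM
compound 3 `CCCn1ccc2c(NCc3cccc(Oc4ccccc4)c3)cccc2c1=O`, 1260 nM

Compound 2 gives the highest number of the three; compound 3 is nearest to it, while compound 1 lies further off. Compound 4 `CCCn1ccc2c(NCc3ccccc3Cl)cccc2c1=O` is not yet measured and differs from compound 2 by chloro in place of hydrogen on an aromatic carbon. For the measured compounds named here, the only measured step on the same aromatic ring is a 1.6-fold lower number from compound 2 to compound 3 (0.20 log units; within the scatter), a substitution on that ring that stayed within the scatter. Going by the values given here, no step with a chloro group is available. On that basis a change no larger than the scatter is expected for compound 4, and a 1.4-fold lower number from compound 2 to compound 4 (0.15 log units; within the scatter) is the estimated step. Compound 4 is expected to give about 1400 nM in this assay, with a range from 500 nM to 4000 nM.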

Compound 4, half-maximal effective concentration: 200 nM
Estimate against measurement, compound 4: 7.0-fold (0.85 log units) above, and the stated range ends above it.
By their numbers in this assay, from the lowest: compounds 4 and 1 (each within the scatter of the next); then compounds 3 and 2 (each within the scatter of the next).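

In this assay, the change from phenyl to 2-chlorophenyl gives a 10-fold lower number from compound 2 to compound 4 (1.00 log units; beyond the scatter) and so moves the number beyond the scatter, whereas the phenoxy substitution on the same ring, a 1.6-fold lower number from compound 2 to compound 3 (0.20 log units; within the scatter), stayed within it. This aromatic ring therefore tolerates substitution and also responds strongly to a single chlorine ortho to a large group. No measurement available here explains the size of this step. Open, going by these compounds, is whether fluoro, methyl or methoxy at this position would give a step of similar size, and whether chloro elsewhere on the ring would do the same.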